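The compounds below may be only part of what the source reports. "The series", "measured", "known", "first", "only" and "open" are said of these compounds alone.

Working notes on the series. In a functional assay on SW707 cells (Homo sapiens) for antiproliferative activity, with a stated time of 72 h (a lower number here means a stronger inhibitor, a higher number a weaker inhibitor), compound 2 `CSc1cnc2ccccc2c1SCC#CCO` gives 34.9 ug/mL, the highest of the two numbers in hand. Compound 1 `CSc1cnc2ccccc2c1[Se]CC#CCCl` gives 3.2 ug/mL. For the measured compounds named here, the two differ only in the chain on an aromatic carbon, and the step of an 11-fold higher number from compound 1 to compound 2 (1.04 log units; beyond the scatter) is the single measured step of the set. Compound 3 `CSc1cnc2ccccc2c1SCC#CCCl` is not yet measured. From compound 2 to compound 3 the change is chloro in place of hydroxy on a saturated chain carbon bound to a triple-bonded carbon. This exchange is one part of the difference between compound 1 and compound 2, while the other part, selenium against sulfur, remains in compound 3. How much of the large step from compound 1 to compound 2 belongs to the chloro-for-hydroxy exchange alone cannot be separated from two numbers. The expectation is a move partway back, stated as a 3.2-fold lower number from compound 2 to compound 3 (0.50 log units; beyond the scatter). Compound 3 is expected at 11 ug/mL, with a range from 4 ug/mL to 30 ug/mL.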

Compound 3, concentration for 50% inhibition: 3.7 ug/mL
Compound 3: the middle estimate sits 3.0-fold (0.47 log units) above what was measured; measured number below the stated range.
By their numbers in this assay, from the lowest: compounds 1 and 3 (each within the scatter of the next); then compound 2.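

In this assay, for the compounds shown here, the chloro in place of hydroxy on a saturated chain carbon bound to a triple-bonded carbon gives a 9.4-fold lower number from compound 2 to compound 3 (0.97 log units; beyond the scatter) with sulfur held constant, the first reading of this exchange on its own. That one exchange matches most of an 11-fold higher number from compound 1 to compound 2 (1.04 log units; beyond the scatter) in size, while sulfur in place of selenium with the chloro kept gives a 1.2-fold higher number from compound 1 to compound 3 (0.06 log units; within the scatter) and so does not separate the two compounds. Among these compounds the end of the chain therefore carries the difference, and the atom linking the chain to the core does not, at least with chloro present.

As far as these compounds go, whether the selenium link behaves the same with hydroxy on the chain stays open, as does what bromo, methoxy or an amine would give on the same saturated chain carbon. Nothing at hand bears on what lies behind the step.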